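Replacing the Pyrazole with a Sulfonamide on the Aromatic Ring

The source may hold more compounds than are shown below. What is called first, only, known or untested is meant among the compounds shown, and "the series" means these compounds.

Of the compounds shown here, three sharing one core have been measured in a functional assay on CHO cells for agonist activity at Alpha-1A adrenergic receptor (Homo sapiens), read by FLIPR and calcium flux; on this read-out lower numbers stand for an effect already at smaller amounts and higher numbers for an effect only at larger amounts of compound. Compound 1 `c1ccc(-c2cccc3c2CCC3c2ncc[nH]2)nc1` gives 1150 nM in this assay. Compound 2 `COc1cccc2c1CCC2c1ncc[nH]1` gives 32 nM. Compound 3 `Cn1nccc1-c1cccc2c1CCC2c1ncc[nH]1` gives 278 nM. Compound 3 thus stands second highest of the three: the step of a 4.1-fold lower number from compound 1 to compound 3 (0.62 log units; beyond the scatter) sets it apart from compound 1, while the step of an 8.7-fold higher number from compound 2 to compound 3 (0.94 log units; beyond the scatter) shows compound 2 lying further off in the other direction, and compound 2 carries the lowest number of the set.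

The next compound, compound 4 `CS(=O)(=O)Nc1cccc2c1CCC2c1ncc[nH]1`, differs from compound 3 in one place: methanesulfonamido in place of 1-methyl-1H-pyrazol-5-yl on an aromatic carbon. Both measured steps bear on this change, since each exchanges the group on that same aromatic carbon. The step of a 4.1-fold lower number from compound 1 to compound 3 (0.62 log units; beyond the scatter) and the step of an 8.7-fold higher number from compound 2 to compound 3 (0.94 log units; beyond the scatter) show that exchanges at this position move the number in this assay by a modest amount in either direction. As methanesulfonamido, like methoxy, is not a ring and contributes a hydrogen-bond donor, compound 4 is expected to land between compound 3 and compound 2, so the step of a 2.3-fold lower number from compound 3 to compound 4 (0.36 log units; beyond the scatter) is expected to run toward a lower number. The estimate for compound 4 is therefore 120 nM, with a range from 25 nM to 600 nM.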

Compound 4, half-maximal effective concentration: 70 nM
Estimate against measurement, compound 4: 1.7-fold (0.23 log units) above; the measured number falls inside the stated range.
By their numbers in this assay, from the lowest: compound 2; then compound 4; then compound 3; then compound 1.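

Compound 4 shows that a second group with no ring at this aromatic carbon also gives a low number in this assay: methanesulfonamido in place of the rings gives a 4.0-fold lower number from compound 3 to compound 4 (0.60 log units; beyond the scatter) and a 16-fold lower number from compound 1 to compound 4 (1.22 log units; beyond the scatter). Among these four compounds, the two groups without a ring, methoxy and methanesulfonamido, therefore both carry lower numbers than the two ring groups, 1-methyl-1H-pyrazol-5-yl and pyridin-2-yl, and no compound shown goes against this order. Methanesulfonamido, with its hydrogen-bond donor, still does not match methoxy, as a 2.2-fold higher number from compound 2 to compound 4 (0.34 log units; beyond the scatter) stays beyond the scatter and leaves compound 2 with the lowest number of the set. Nothing shown here accounts for these differences.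

The compounds shown leave open whether the amide hydrogen of the methanesulfonamido group matters, which a sulfonamide with a methyl group on its nitrogen would test, and how a plain amine or an acetamido group would compare at the same carbon. They also leave open whether a longer chain on the sulfonyl group, such as ethyl in place of methyl, would keep the number near that of compound 4.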